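Working notes: methyl for phenyl on the tetrazole nitrogen

A few compounds are considered here, and "the series" means these few. Any claim that something is new, unique, unknown or untested is made for them only; others in the source may bear on it.

Measured so far:
compound 1 `O=C(CSc1nnnn1-c1ccccc1)N/N=c1/scc(-c2ccc(Br)cc2)n1-c1ccccc1`: 433 ug/mL
compound 2 `COc1ccc(-c2cs/c(=N/NC(=O)CSc3nnnn3-c3ccccc3)n2-c2ccccc2)cc1`: 11.7 ug/mL

In an ADME assay on NIH3T3 cells (Mus musculus) for cytotoxicity, read by MTT assay, with a stated time of 24 h (a higher number here means a weaker inhibitor, a lower number a stronger inhibitor), compound 1 gives 433 ug/mL, the highest of the two numbers shown; compound 2 gives 11.7 ug/mL, and the single measured step is a 37-fold lower number from compound 1 to compound 2 (1.57 log units; beyond the scatter).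

Compound 3 `Cn1nnnc1SCC(=O)N/N=c1/scc(-c2ccc(Br)cc2)n1-c1ccccc1` differs from compound 1 by methyl in place of phenyl on an aromatic nitrogen. This change sits on the tetrazole, far from the aromatic carbon altered in the step from compound 1 to compound 2, so that step does not bear on it. Within the data shown here, no measured pair in this set varies the group on the tetrazole nitrogen, and no comparison here shows that such a change moves the number.

With nothing to anchor a shift, the expected step of a 1.1-fold lower number from compound 1 to compound 3 (0.03 log units; within the scatter) is none beyond the scatter. Compound 3 is therefore estimated at 400 ug/mL, with a wide range from 120 ug/mL to 1000 ug/mL in this assay.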

Compound 3, half-maximal inhibitory concentration: 19.3 ug/mL
The estimate for compound 3 lay 21-fold (1.32 log units) above the measured number; measured number below the stated range.
By their numbers in this assay, from the lowest: compounds 2 and 3 (each within the scatter of the next); then compound 1.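

In this assay, the group on the tetrazole nitrogen is not a silent position: methyl in place of phenyl gives a 22-fold lower number from compound 1 to compound 3 (1.35 log units; beyond the scatter), a large step beyond the scatter. The high number of compound 1 therefore does not depend on the bromo group alone, since a single change at either of two separate places lowers it, the other step being a 37-fold lower number from compound 1 to compound 2 (1.57 log units; beyond the scatter). No measurement shown gives a reason for the step at the tetrazole nitrogen.

On these data alone, it remains open whether the step follows from the departure of phenyl or from methyl itself, a question that an ethyl or benzyl group on the same nitrogen would help to settle. Also open, as far as these compounds go, is whether the step holds when methoxy stands in place of bromo on the aromatic carbon.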